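Nitro in place of methoxy on the shared core

The source may hold more compounds than are shown below. What is called first, only, known or untested is meant among the compounds shown, and "the series" means these compounds.

Of the compounds shown here, two carry numbers so far: compound 1, `CCOC(=O)C(=O)Nc1cccc(OC)c1C#N`, and compound 2, `CCOC(=O)C(=O)Nc1cccc(N)c1C#N`. In a functional assay on the whole organism with Rattus norvegicus as the target (a lower number here means that less compound is needed, a higher number that more compound is needed for the effect), compound 1 gives 5.3 mg/kg, the higher of the two numbers; compound 2 gives 0.05 mg/kg. Among the compounds with values here, the only measured step, a 110-fold lower number from compound 1 to compound 2 (2.03 log units; beyond the scatter), is large and beyond the scatter. Within the data shown here, compound 3, `CCOC(=O)C(=O)Nc1cccc([N+](=O)[O-])c1C#N`, is unmeasured. nitro in place of methoxy on an aromatic carbon The amino step is the only one that touches this ring carbon, but nitro is a different entering group, so it bears on compound 3 only loosely: no measured pair shows nitro at all. The expectation is therefore a step of modest size in this assay, without a firm direction, with a wide range. Compound 3 is estimated at 4 mg/kg, range 0.8 mg/kg to 25 mg/kg. This expected step, a 1.3-fold lower number from compound 1 to compound 3 (0.12 log units; within the scatter), lies within the scatter.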

Compound 3, dose for half-maximal effect: 0.4 mg/kg
Beside the measured number, compound 3's estimate is 10-fold (1.00 log units) above it, and the stated range ends above it.
By their numbers in this assay, from the lowest: compound 2; then compound 3; then compound 1.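

In this assay, the lower number is no longer tied to amino alone, since nitro in place of methoxy on this aromatic carbon, ortho to a cyano group, also gives a large step beyond the scatter (a 13-fold lower number from compound 1 to compound 3 (1.12 log units; beyond the scatter)). The entering group still matters at this carbon, as nitro and amino are separated by a modest step that is also beyond the scatter (an 8.0-fold higher number from compound 2 to compound 3 (0.90 log units; beyond the scatter)). Nothing available bears on why these groups differ.

The compounds shown leave open where a hydroxyl group or a methylamino group on this carbon would fall relative to amino and nitro. They also leave open whether the same order holds with a carboxylic acid in place of the ethyl ester.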